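The compounds below may be only part of what the source reports. "The series", "measured", "known", "first", "only" and "open" are said of these compounds alone.

Working notes on the series. Three compounds share one core and differ only in the group on the aromatic carbon of the six-membered ring. Compound 1 `O=C1NCCC12CCN(c1c(Cl)cncc1-c1ccsc1)CC2` gives 190 nM in a functional assay on MV4-11 cells (Homo sapiens) for inhibition, read by resazurin assay, with a stated time of 72 h; on this read-out lower numbers stand for stronger inhibition of growth and higher numbers for weaker inhibition of growth. Compound 2 `O=C1NCCC12CCN(c1c(Cl)cncc1-c1cc[nH]c1)CC2` gives 1050 nM, and compound 3 `Cc1ccc(-c2cncc(Cl)c2N2CCC3(CCNC3=O)CC2)o1` gives 4950 nM. Compound 3 thus holds the highest number of the three: compound 2 lies nearest, the step being a 4.7-fold higher number from compound 2 to compound 3 (0.67 log units; beyond the scatter), and compound 1 lies furthest, the step being a 26-fold higher number from compound 1 to compound 3 (1.42 log units; beyond the scatter). The step of a 5.5-fold higher number from compound 1 to compound 2 (0.74 log units; beyond the scatter) is the third comparison.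

Compound 4 `O=Cc1cc(-c2cncc(Cl)c2N2CCC3(CCNC3=O)CC2)cs1` is not yet measured. Its change from compound 3 is 5-formylthiophen-3-yl in place of 5-methylfuran-2-yl on an aromatic carbon. The step that bears most on it is the one in the opposite direction, from compound 1 to compound 3, where the thiophen-3-yl was replaced by the 5-methylfuran-2-yl with a large rise in number. Going by the values given here, compound 4 restores a thiophen-3-yl, now carrying a formyl; no measured pair shows what a formyl on this ring does, so that part stays open. A drop well beyond the scatter is expected, of about an 11-fold lower number from compound 3 to compound 4 (1.04 log units; beyond the scatter), short of a full return to compound 1 to allow for the added formyl. Compound 4 is therefore expected near 450 nM, within 130 nM to 1600 nM.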

Compound 4, concentration for 50% growth inhibition: 730 nM
The estimate for compound 4 lay 1.6-fold (0.21 log units) below the measured number; measured number inside the range.
By their numbers in this assay, from the lowest: compound 1; then compounds 4 and 2 (each within the scatter of the next); then compound 3.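

In this assay, going by these compounds alone, the formyl is the first change made on the thiophen-3-yl itself, and placing it in position of hydrogen on that ring gives a modest loss (a 3.8-fold higher number from compound 1 to compound 4 (0.58 log units; beyond the scatter)), a result no earlier pair could show. The 5-formylthiophen-3-yl still keeps much of the advantage over the 5-methylfuran-2-yl (a 6.8-fold lower number from compound 3 to compound 4 (0.83 log units; beyond the scatter)), so the formyl does not cancel the whole gap between the thiophen-3-yl of compound 1 and the 5-methylfuran-2-yl of compound 3. Against the 1H-pyrrol-3-yl the step lies within the scatter (a 1.4-fold lower number from compound 2 to compound 4 (0.16 log units; within the scatter)), so these two groups cannot be told apart on this read-out, although one carries the formyl and the other does not.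

Nothing at hand gives a cause for any of these steps. As far as these compounds go, it stays open whether the loss belongs to the formyl in particular, which a hydroxymethyl, a carboxylic acid or an aminomethyl on the same thiophene ring would test, and whether a plain furan-2-yl would show that the weak number of compound 3 comes from the furan ring or from its methyl.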